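From compound 1 to compound 4: an added methoxymethyl

The source may hold more compounds than are shown below. What is called first, only, known or untested is meant among the compounds shown, and "the series" means these compounds.

In a physicochemical assay for solubility, in phosphate buffer, at pH 7.4 (on this read-out higher numbers stand for higher solubility and lower numbers for lower solubility), compound 1 (`CCn1cc(C(=O)C(=O)Nc2ccc(OC)nc2)c2ccccc21`) gives 10000 nM as its reading. Compound 2 (`COc1ccc(NC(=O)C(=O)c2cc(C(C)C)n3ccccc23)cn1`) gives 10000 nM in this assay and so stands level with compound 1 at the digits shown. The reading for compound 3 (`COc1ccc(NC(=O)C(=O)c2cn(CCC(=O)O)c3ccccc23)cn1`) is <= 200000 nM and it is a limit, not a number.

Compound 4 (`COCC(C)n1cc(C(=O)C(=O)Nc2ccc(OC)nc2)c2ccccc21`) has not yet been measured. It differs from compound 1 by methoxymethyl in place of hydrogen on a saturated chain carbon bound to an aromatic nitrogen and a saturated chain carbon. Within the data shown here, the only measured step, carboxy in place of hydrogen on a saturated chain carbon, is a step that the limit leaves unreadable from compound 1 to compound 3 and offers no size to carry over. With nothing readable pointing either way, the expected step is no change at the digits printed from compound 1 to compound 4 (within the scatter) in this assay and no shift beyond the scatter is foreseen. Compound 4 is estimated in this assay at 10000 nM with a range from 3000 nM to 35000 nM expected for it.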

Compound 4, solubility: 40000 nM
Estimate against measurement, compound 4: 4.0-fold (0.60 log units) below; measured number above the stated range.
By their numbers in this assay, from the lowest: compounds 1 and 2 (each within the scatter of the next); then compound 4.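

In this assay, methoxymethyl in place of hydrogen on a saturated chain carbon bound to an aromatic nitrogen and a saturated chain carbon gives a 4.0-fold higher number from compound 1 to compound 4 (0.60 log units; beyond the scatter), a step beyond the scatter. Among these compounds, this is the first readable step at this position: the earlier compounds gave no step of readable size here, and the chain on the aromatic nitrogen now proves able to move the number. The steps that involve compound 3 still cannot be read, its value being a limit: the limit of <= 200000 nM in this assay, at which 1 of the 4 values shown sits.

From the compounds shown here alone, it remains open whether the oxygen of the methoxymethyl group matters, or whether a plain methyl or ethyl group in the same place would give a step of similar size. Going by these compounds, how an amine such as dimethylaminomethyl would compare at this position also stays unknown.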